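Oxetan-3-yl for methyl on an aromatic nitrogen

A few compounds are considered here, and "the series" means these few. Any claim that something is new, unique, unknown or untested is made for them only; others in the source may bear on it.

Measured in an assay on isolated protein for inhibition of Leucine-rich repeat serine/threonine-protein kinase 2 variant G2019S (Homo sapiens), read by TR-FRET and LanthaScreen, with stated times of 50 min and 30 min, in the presence of a further agent that is not named here; on this read-out lower numbers stand for stronger inhibition and higher numbers for weaker inhibition:
compound 1 `Cc1c(Nc2nc(N)c3c(C#N)c(N4CCC[C@H]4C)n(C)c3n2)cnn1C`: 43 nM
compound 2 `Cc1cn(C)nc1Nc1cc2c(c(N)n1)c(C#N)c(N1CCC[C@H]1C)n2C`: 1290 nM
compound 3 `CN(C)c1c(C#N)c2c(N)ncnc2n1C`: 3760 nM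

Compound 1 gives the lowest number of the three; compound 2 stands higher by a margin beyond the usual scatter, and compound 3 higher still. Going by the values given here, no pair among the measured compounds differs in a single place, so no measured step is available to lean on.

Compound 4 `Cc1c(Nc2nc(N)c3c(C#N)c(N4CCC[C@H]4C)n(C)c3n2)cnn1C1COC1` differs from compound 1 by oxetan-3-yl in place of methyl on an aromatic nitrogen. Among the compounds with values here, with no comparable step in the set, the change is expected to leave the read-out essentially where compound 1 sits: the step from compound 1 to compound 4 is estimated at a 1.2-fold higher number from compound 1 to compound 4 (0.07 log units; within the scatter), not beyond the scatter. Compound 4 is therefore expected near 50 nM, within a range from 15 nM to 160 nM.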

Compound 4, half-maximal inhibitory concentration: 37 nM
Compound 4: middle estimate off by 1.4-fold (0.13 log units), on the high side; the measured number falls inside the stated range.
By their numbers in this assay, from the lowest: compounds 4 and 1 (each within the scatter of the next); then compound 2; then compound 3.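

In this assay, going by these compounds alone, a 1.2-fold lower number from compound 1 to compound 4 (0.07 log units; within the scatter) is a step within the scatter, the first single-place comparison. The aromatic nitrogen therefore accepts oxetan-3-yl, with its four-membered non-aromatic ring, as well as it accepts methyl on the core of compound 1. No evidence accounts for this tolerance. On these data alone, whether the same position also accepts a larger ring such as piperidin-4-yl, an amine or a longer chain ending in a carboxylic acid remains open. Also open, as far as these compounds go, is whether the swap behaves the same way on the core of compound 2.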